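The source may hold more compounds than are shown below. What is called first, only, known or untested is meant among the compounds shown, and "the series" means these compounds.

Measured in a functional assay on A549 cells (Homo sapiens) for antiproliferative activity, read by MTT assay, with a stated time of 48 h; on this read-out lower numbers stand for stronger inhibition and higher numbers for weaker inhibition:
- compound 1 `CCCCCCC1(O)C(=O)Nc2ccc(Nc3ccc(OC)cc3)cc21`: 18600 nM
- compound 2 `CCCCCCC1(O)C(=O)Nc2ccc(Nc3ccc(C)cc3)cc21`: 12100 nM
- compound 3 `CCCCCC1(O)C(=O)Nc2ccc(Nc3ccc(F)cc3)cc21`: 5900 nM

Compound 3 has the lowest number of the three, and its gaps to compound 2 and compound 1 both lie beyond the scatter. Compound 4 `CCCCCCC1(O)C(=O)Nc2ccc(Nc3ccc(F)cc3)cc21` has not yet been measured in this assay. It differs from compound 3 by a single change: methyl in place of hydrogen on a saturated chain carbon, five bonds along the chain from a saturated ring carbon.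

Among the measured compounds shown here, no measured step covers this change. The only one available, a 1.5-fold lower number from compound 1 to compound 2 (0.19 log units; within the scatter), concerns methyl in place of methoxy on an aromatic carbon, a different kind of change. Compound 1 and compound 2 carry the hexyl chain of compound 4 and have higher numbers than compound 3, but they also lack its fluoro group, so the data cannot separate the two differences. A small rise, not clearly beyond the scatter, is therefore expected, and the estimated step is a 1.3-fold higher number from compound 3 to compound 4 (0.10 log units; within the scatter). For compound 4 the expected value is 7500 nM, with an estimated range of 3800 nM to 14000 nM.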

Compound 4, half-maximal inhibitory concentration: 12000 nM
Compound 4: middle estimate off by 1.6-fold (0.20 log units), on the low side, within the range that was stated.
By their numbers in this assay, from the lowest: compound 3; then compounds 4, 2 and 1 (each within the scatter of the next).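

In this assay, methyl in place of hydrogen on a saturated chain carbon, five bonds along the chain from a saturated ring carbon, gives a 2.0-fold higher number from compound 3 to compound 4 (0.31 log units; beyond the scatter), and this is the only single change shown whose step lies beyond the scatter. With the hexyl chain held the same, the aromatic substituent does not separate the compounds: fluoro in place of methyl gives a 1.0-fold lower number from compound 2 to compound 4 (0.00 log units; within the scatter), and fluoro in place of methoxy gives a 1.6-fold lower number from compound 1 to compound 4 (0.19 log units; within the scatter). No measured evidence bears on why the chain change shifts the number.

The compounds shown leave open whether a longer chain, or a chain carrying an amine, would shift the number further. They also leave open whether methyl or methoxy in place of fluoro would give similar steps on the shorter chain of compound 3.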